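From nitro to amino on the sulfonyl aryl group

The compounds below may be only part of what the source reports. "The series", "measured", "known", "first", "only" and "open" are said of these compounds alone.

Values in a functional assay on K562 cells (Homo sapiens) for inhibition, read by trypan blue exclusion, with a stated time of 72 h; a higher number here means a weaker inhibitor, a lower number a stronger inhibitor:
Compound 1 `Cn1c(=O)c(S(=O)(=O)c2ccc(Cl)cc2Cl)cc2cnc(Nc3ccc4[nH]ccc4c3)nc21`: 1000 nM
Compound 2 `Cn1c(=O)c(C(=O)Nc2ccc(F)cc2F)cc2cnc(Nc3ccc4[nH]ccc4c3)nc21`: 5000 nM
Compound 3 `Cn1c(=O)c(S(=O)(=O)c2ccc(F)cc2[N+](=O)[O-])cc2cnc(Nc3ccc4[nH]ccc4c3)nc21`: 900 nM

In this assay compound 3 gives 900 nM. This cannot be told apart from compound 1, as a 1.1-fold lower number from compound 1 to compound 3 (0.05 log units; within the scatter) shows, while compound 2 stands clear of both at 5000 nM.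

The next compound, compound 4 `Cn1c(=O)c(S(=O)(=O)c2ccc(F)cc2N)cc2cnc(Nc3ccc4[nH]ccc4c3)nc21`, has not yet been measured. It carries amino in place of nitro on an aromatic carbon, ortho to a large group and meta to a fluoro group, so that 4-fluoro-2-nitrophenyl becomes 2-amino-4-fluorophenyl: amino in place of nitro on an aromatic carbon.

Among the compounds with values here, no measured step makes this exact change. The closest evidence is a 1.1-fold lower number from compound 1 to compound 3 (0.05 log units; within the scatter), which also alters only the aryl group on the sulfonyl sulfur. The larger 5.0-fold higher number from compound 1 to compound 2 (0.70 log units; beyond the scatter) exchanges the whole (2,4-dichlorophenyl)sulfonyl for (2,4-difluorophenyl)carbamoyl, so it bears less on a swap confined to one ring substituent. A single comparison is thin ground, but no step beyond the scatter is expected in this assay, and no direction can be argued. The expected change is a 1.1-fold lower number from compound 3 to compound 4 (0.05 log units; within the scatter). Compound 4 is estimated at 800 nM, with an expected range from 300 nM to 2200 nM.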

Compound 4, half-maximal inhibitory concentration: 2000 nM
Estimate against measurement, compound 4: 2.5-fold (0.40 log units) below; low and high end bracket the measured number.
By their numbers in this assay, from the lowest: compounds 3, 1 and 4 (each within the scatter of the next, the first and the last beyond it); then compound 2.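

In this assay, the exchange of nitro for amino on the aromatic carbon ortho to a large group gives a step beyond the scatter (a 2.2-fold higher number from compound 3 to compound 4 (0.35 log units; beyond the scatter)), which shows that the number responds to this one substituent, something the earlier change of aryl group on the sulfonyl sulfur did not reveal (a 1.1-fold lower number from compound 1 to compound 3 (0.05 log units; within the scatter)). The response is modest and does not separate the new aryl group from 2,4-dichlorophenyl (a 2.0-fold higher number from compound 1 to compound 4 (0.30 log units; within the scatter)), while the sulfonyl series with 2-amino-4-fluorophenyl remains clearly apart from the carbamoyl compound (a 2.5-fold lower number from compound 2 to compound 4 (0.40 log units; beyond the scatter)). Nothing measured here accounts for the size or the direction of the nitro to amino step.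

The compounds shown leave open whether the step comes from losing nitro or from gaining amino, since only these two groups have been compared at this position with the 4-fluoro group kept in place. A hydroxyl group, a methoxy group, a dimethylamino group or an acetamide at the same carbon would help to separate those two readings, and would show how far the number moves with other groups there.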